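A few compounds are considered here, and "the series" means these few. Any claim that something is new, unique, unknown or untested is made for them only; others in the source may bear on it.

Compound 1 `Cc1ccc(S(=O)(=O)/C(=C/c2sccc2C)C(=O)c2ccc(Cl)cc2)cc1`: 10000 nM
Compound 2 `Cc1ccc(S(=O)(=O)/C(=C/c2sccc2C)C(=O)c2ccc(Br)cc2)cc1`: 25000 nM
Compound 3 `O=C(O)c1ccc(C(=O)/C(=C\c2ccc(Cl)c([N+](=O)[O-])c2)SCc2ccccc2F)cc1`: 1000 nM

In a functional assay on DU-145 cells (Homo sapiens) for inhibition, read by trypan blue exclusion, with a stated time of 96 h (on this read-out higher numbers stand for weaker inhibition of growth and lower numbers for stronger inhibition of growth), compound 2 stands at the highest number of the three: compound 1 lies below it by a 2.5-fold higher number from compound 1 to compound 2 (0.40 log units; beyond the scatter), and compound 3 lies far lower still. Compound 4 `Cc1ccc(S(=O)(=O)/C(=C/c2c[nH]c3ccccc23)C(=O)c2ccc(Br)cc2)cc1` differs from compound 2 by 1H-indol-3-yl in place of 3-methylthiophen-2-yl on a double-bonded chain carbon bound to a double-bonded chain carbon. Among the measured compounds shown here, no measured step touches this part of the shared core; the only measured step, a 2.5-fold higher number from compound 1 to compound 2 (0.40 log units; beyond the scatter), concerns a halogen on a different ring and says nothing about the group on the double-bonded chain carbon. Without a relevant step, little change beyond the scatter is expected, and compound 4 is estimated at 15000 nM, between 4000 nM and 50000 nM, which is expected to mean a step of a 1.7-fold lower number from compound 2 to compound 4 (0.22 log units; within the scatter).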

Compound 4, concentration for 50% growth inhibition: 10000 nM
The estimate for compound 4 lay 1.5-fold (0.18 log units) above the measured number, within the range that was stated.
By their numbers in this assay, from the lowest: compound 3; then compounds 1 and 4 (each within the scatter of the next); then compound 2.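

In this assay the group on the double-bonded chain carbon proves able to shift the result: 1H-indol-3-yl in place of 3-methylthiophen-2-yl gives a 2.5-fold lower number from compound 2 to compound 4 (0.40 log units; beyond the scatter), a modest step beyond the scatter. So this position responds to change, and the added six-membered aromatic ring and hydrogen-bond donor come with stronger, not weaker, growth inhibition. No measurement on hand explains this shift. On these data alone, it remains open how a plain phenyl ring or a pyridine ring would compare at this position, and whether chloro in place of bromo would change the result with 1H-indol-3-yl present.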